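Swapping a cyclopentyl for a methoxyphenyl on a quinone core

The source may hold more compounds than are shown below. What is called first, only, known or untested is meant among the compounds shown, and "the series" means these compounds.

Three compounds share one core and differ only in the group carried on the ring carbon opposite the two carbonyls. Compound 1 `O=C1C=C(N2CCC2)C(=O)c2c1nc1n2[C@H]2OC[C@@H](O)[C@H]2OC1` carries an azetidin-1-yl group, compound 2 `O=C1C(NC2CCCC2)=CC(=O)c2c1nc1n2[C@H]2OC[C@@H](O)[C@H]2OC1` a cyclopentylamino group, and compound 3 `O=C1C=C(Nc2ccccc2F)C(=O)c2c1nc1n2[C@H]2OC[C@@H](O)[C@H]2OC1` a (2-fluorophenyl)amino group. In a functional assay on HeLa cells (Homo sapiens) for inhibition, read by sulforhodamine B assay (on this read-out lower numbers stand for stronger inhibition and higher numbers for weaker inhibition), compound 1 gives > 16000 nM, which is a limit of the assay rather than a number. Compound 2 likewise gives > 16000 nM in this assay, again a limit. Compound 3 gives 5120 nM in this assay, a real number. So compound 2 sits at the weak end of what has been measured, sharing (the limit of > 16000 nM in this assay, at which 2 of the 3 values shown sit).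

The untested compound 4 `COc1cccc(NC2=CC(=O)c3c(nc4n3[C@H]3OC[C@@H](O)[C@H]3OC4)C2=O)c1` differs from compound 2 in one place: 3-methoxyphenyl in place of cyclopentyl on an amine nitrogen. Going by the values given here, the only measured step that speaks to this is the one from the small saturated ring to the aromatic amine, an at least 3.1-fold lower number from compound 1 to compound 3 (0.49 log units; beyond the scatter), which moved the number downward out of the limit. The change to compound 4 is of the same kind, a saturated ring giving way to an aromatic one, so a drop of comparable size is expected, an at least 2.6-fold lower number from compound 2 to compound 4 (0.42 log units; beyond the scatter). Compound 4 is therefore estimated at 6000 nM, between 2500 nM and 16000 nM in this assay.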

Compound 4, half-maximal inhibitory concentration: > 8000 nM
Compound 4: only a limit was reported; the forecaster's own chance of this, stated with the estimate: 25%; at least 1.3-fold (0.12 log units) between middle value and limit.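

In this assay compound 4 gives > 8000 nM, a limit and not a number. Compound 2 gives > 16000 nM, also a limit, so the step from one to the other cannot be read. The compounds shown leave open whether 3-methoxyphenyl in place of cyclopentyl on an amine nitrogen lowers the number, raises it or leaves it unchanged.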